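Furan-2-yl for 4-methoxyphenyl on the nitrooxyacetamide chalcone

The source may report more compounds than this note shows. Statements on the series, on what has been measured and on what is new or still open speak of the compounds shown alone.

Working notes on the series, read in a functional assay on the whole organism (strain albino) for inhibition, with Rattus norvegicus as the target, read by paw edema, with stated times of 30 min and 4 h, at a dose of 100 mg/kg by the oral route; on this read-out lower numbers stand for less inhibition and higher numbers for more inhibition at the one dose given (going by the name of the read-out). Compound 3 `COc1ccc(/C=C/C(=O)c2ccc(NC(=O)CO[N+](=O)[O-])cc2)cc1` gives 51%, the highest of the three numbers, with both other compounds beyond the scatter below it. Compound 1 `Nc1ccc(C(=O)/C=C/c2ccco2)cc1` gives 33% and compound 2 `O=C(CBr)Nc1ccc(C(=O)/C=C/c2ccco2)cc1` gives 33%; the step of no change at the digits printed from compound 1 to compound 2 (within the scatter) shows that a substituent on the amide nitrogen left the read-out unmoved. Compound 4 `O=C(CO[N+](=O)[O-])Nc1ccc(C(=O)/C=C/c2ccco2)cc1` differs from compound 3 by furan-2-yl in place of 4-methoxyphenyl on a double-bonded chain carbon bound to a double-bonded chain carbon. Among the measured compounds shown here, no measured step exchanges these two aryl groups, so the only guide is that compound 1 and compound 2, which carry the furan-2-yl, sit at a lower level than compound 3. A drop toward that level is therefore expected, a number 13 percentage points lower from compound 3 to compound 4 (beyond the scatter). The estimate for compound 4 is 38%, expected to range from 28% to 50%.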

Compound 4, a percentage reported as inhibition, in the whole organism at one dose (the size of the read-out at that dose, not a potency): 40%
Compound 4: middle estimate off by 2 percentage points, on the low side; the measured number falls inside the stated range.
By their numbers in this assay, from the lowest: compounds 1, 2 and 4 (each within the scatter of the next); then compound 3.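

Furan-2-yl in place of 4-methoxyphenyl gives a number 11 percentage points lower from compound 3 to compound 4 (beyond the scatter) in this assay as a modest step, a direct reading of this exchange on the double-bonded chain carbon. With furan-2-yl held, nitrooxy in place of bromo gives a number 7 percentage points higher from compound 2 to compound 4 (within the scatter) and ((nitrooxy)methyl)carbonyl in place of hydrogen on the nitrogen gives a number 7 percentage points higher from compound 1 to compound 4 (within the scatter) and so neither change separates these compounds. No evidence on the origin of these steps is at hand.

Open, going by these compounds, is whether another aryl group at this place, such as unsubstituted phenyl or thiophen-2-yl, would read with compound 3 or compound 4. Also open, on these data alone, is whether the 4-methoxyphenyl step holds with bromo or a free amine in place of the nitrooxy-bearing chain.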